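The source may hold more compounds than are shown below. What is called first, only, known or untested is meant among the compounds shown, and "the series" means these compounds.

Working notes on the series. Compound 1 `ClCc1ccc(Cn2cnc3nc(Cl)nc(Cl)c32)cc1` carries two chloro groups on its fused core; in a functional assay on NCI-H322M cells (Homo sapiens) for cytotoxicity, read by sulforhodamine B assay, with a stated time of 48 h (a higher number here means that more compound is tolerated, a lower number that less compound is tolerated), compound 1 gives 4460 nM. Within the data shown here, compound 2 `ClCc1cccc(Cn2cnc3c(Cl)nc(Cl)nc32)c1` is the only other measured member, and in this assay compound 2 gives 15900 nM. Compound 1 thus stands at the lowest of the two numbers measured, with compound 2 showing a higher one that lies beyond the scatter of repeated measurements. Among the measured compounds shown here, no step between two measured compounds that differ in a single place is available, so nothing in the measured set directly tells how one chloro contributes.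

Compound 3 `ClCc1ccc(Cn2cnc3ncnc(Cl)c32)cc1` is not yet measured. It differs from compound 1 by hydrogen in place of chloro on an aromatic carbon. For the measured compounds named here, with no matching step to lean on, the expectation for compound 3 is a step of a 1.8-fold higher number from compound 1 to compound 3 (0.25 log units; within the scatter) toward a higher number, of modest size and not safely beyond the scatter. The estimate for compound 3 in this assay is 8000 nM, within a range from 2500 nM to 25000 nM.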

Compound 3, concentration lethal to 50% of the cells: 5620 nM
Compound 3: the middle estimate sits 1.4-fold (0.15 log units) above what was measured; the range from low to high includes it.
By their numbers in this assay, from the lowest: compounds 1 and 3 (each within the scatter of the next); then compound 2.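

Compound 3 gives the series its first single-place comparison: in this assay, hydrogen in place of chloro on the aromatic carbon between two ring nitrogen atoms gives a 1.3-fold higher number from compound 1 to compound 3 (0.10 log units; within the scatter). At this position, then, the two substituents are not told apart in this assay, and the level seen for compound 1 does not depend on this chloro group. Nothing available explains why the two compounds read alike.

From the compounds shown here alone, whether an amine or a methoxy group on the same carbon would also leave the number within the scatter remains open, so the tolerance of this position is known only for chloro and hydrogen. The contribution of the chloro group that compounds 1 and 3 share also remains unread, since no compound shown replaces it alone.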